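A few compounds are considered here, and "the series" means these few. Any claim that something is new, unique, unknown or untested is made for them only; others in the source may bear on it.

Compound 1 `CC1(C[C@@H](O)C(=O)N2[C@@H]3C[C@@H]3C[C@H]2C(=O)NCc2cc(Cl)ccc2-n2cnnn2)CC1` gives 1300 nM in a functional assay on a cell-free system (plasma, Homo sapiens), with a stated time of 3 min; a higher number here means a weaker inhibitor, a lower number a stronger inhibitor.
Compound 2 `CC(C)(C)C[C@@H](O)C(=O)N1[C@@H]2C[C@@H]2C[C@H]1C(=O)NCc1cc(Cl)ccc1-n1cnnn1` gives 520 nM in this assay.
Compound 3 `CC(C)(C)[C@@H](O)C(=O)N1[C@@H]2C[C@@H]2C[C@H]1C(=O)NCc1cc(Cl)ccc1-n1cnnn1` gives 1100 nM in this assay.

Compound 3 stands second highest of the three numbers. The step of a 1.2-fold lower number from compound 1 to compound 3 (0.07 log units; within the scatter) lies within the scatter, so the numbers of compound 3 and compound 1 cannot be told apart, while the step of a 2.1-fold higher number from compound 2 to compound 3 (0.33 log units; beyond the scatter) is modest but beyond the scatter. Compound 4 `O=C(NCc1cc(Cl)ccc1-n1cnnn1)[C@@H]1C[C@H]2C[C@H]2N1C(=O)[C@H](O)c1cccc(F)c1` has not yet been measured in this assay. It differs from compound 3 in one place: 3-fluorophenyl in place of tert-butyl on a saturated chain carbon bound to a carbonyl carbon and an oxygen on a saturated carbon. The two known steps at this place, a 1.2-fold lower number from compound 1 to compound 3 (0.07 log units; within the scatter) and a 2.1-fold higher number from compound 2 to compound 3 (0.33 log units; beyond the scatter), each exchange one saturated group for another, and both stay small. Among the measured compounds shown here, none of the measured compounds carries an aromatic ring at this place, so the move to 3-fluorophenyl has no direct precedent; the measured steps only show that changes here have moved the number modestly. For compound 4 the expected step is a 1.4-fold lower number from compound 3 to compound 4 (0.14 log units; within the scatter), with no direction claimed beyond the scatter. Compound 4 is therefore estimated at 800 nM, within a range from 250 nM to 2500 nM.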

Compound 4, half-maximal inhibitory concentration: 1100 nM
Beside the measured number, compound 4's estimate is 1.4-fold (0.14 log units) below it; measured number inside the range.
By their numbers in this assay, from the lowest: compound 2; then compounds 3, 4 and 1 (each within the scatter of the next).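

Until now, only saturated groups had been seen on this saturated chain carbon bound to a carbonyl carbon and an oxygen on a saturated carbon. Compound 4 adds an aromatic case in this assay: replacing tert-butyl (4 heavy atoms, no ring) with 3-fluorophenyl (7 heavy atoms, one six-membered aromatic ring) gives no change at the digits printed from compound 3 to compound 4 (within the scatter) and so leaves the number unmoved despite the larger group. The comparison with the other saturated groups gives a 1.2-fold lower number from compound 1 to compound 4 (0.07 log units; within the scatter) within the scatter and a 2.1-fold higher number from compound 2 to compound 4 (0.33 log units; beyond the scatter) beyond it, so the neopentyl group of compound 2 still has the lowest number of the four, while no evidence here explains this pattern.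

Still open, from the compounds shown here alone, is what the fluorine contributes, which a plain phenyl group at this place could help to answer, along with whether a different placement of the fluorine on the ring would matter. Also open, going by these compounds, is how this position would respond to a group carrying an amine or a carboxylic acid, since tert-butyl and 3-fluorophenyl both carry no net charge.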